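Sulfonamide series: working notes toward compound 4

A few compounds are considered here, and "the series" means these few. Any claim that something is new, unique, unknown or untested is made for them only; others in the source may bear on it.

Measured so far:
compound 1 `Cc1cc(C)cc(NS(=O)(=O)c2ccc(N3CCNC3=O)cc2)c1`: 100 nM
compound 2 `Cc1cccc(NS(=O)(=O)c2ccc(N3CCNC3=O)cc2)c1`: 190 nM
compound 3 `O=C1NCCN1c1ccc(S(=O)(=O)Nc2ccc(Cl)cc2)cc1`: 170 nM

All three numbers come from a functional assay on MCF7 cells (Homo sapiens) for antiproliferative activity, read by sulforhodamine B assay, with a stated time of 48 h; on this read-out higher numbers stand for weaker inhibition and lower numbers for stronger inhibition. Compound 3 gives the second highest of the three numbers; its nearest neighbour is compound 2, at a 1.1-fold lower number from compound 2 to compound 3 (0.05 log units; within the scatter), and its furthest is compound 1, at a 1.7-fold higher number from compound 1 to compound 3 (0.23 log units; within the scatter). All three values sit within the scatter of one another, so no order among them can be read.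

Compound 4 `CCc1cccc(NS(=O)(=O)c2ccc(N3CCNC3=O)cc2)c1` has not been measured. It differs from compound 3 in one place: 3-ethylphenyl in place of 4-chlorophenyl on a sulfonamide nitrogen. Among the measured compounds shown here, two measured steps bear on this. The step of a 1.1-fold lower number from compound 2 to compound 3 (0.05 log units; within the scatter) concerns a change of the group on the same sulfonamide nitrogen and runs the opposite way to the present one; it stayed within the scatter. The step of a 1.9-fold higher number from compound 1 to compound 2 (0.28 log units; within the scatter), hydrogen in place of methyl on an aromatic carbon, also stayed within the scatter. For the measured compounds named here, nothing so far shows a move beyond the scatter for any change at this position, and no measured compound carries 3-ethylphenyl, so that group itself is untested. The expected step from compound 3 to compound 4 is therefore a 1.1-fold lower number from compound 3 to compound 4 (0.03 log units; within the scatter), with no direction beyond the scatter. Compound 4 is expected to give 160 nM in this assay, within a range of 80 nM to 320 nM.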

Compound 4, half-maximal inhibitory concentration: 130 nM
Compound 4: the middle estimate sits 1.2-fold (0.09 log units) above what was measured; low and high end bracket the measured number.
By their numbers in this assay, from the lowest: compounds 1, 4, 3 and 2 (each within the scatter of the next).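

In this assay, 3-ethylphenyl on the sulfonamide nitrogen now has a value of its own, and its steps to both other substituted rings stay within the scatter: 4-chlorophenyl (a 1.3-fold lower number from compound 3 to compound 4 (0.12 log units; within the scatter)) and 3,5-dimethylphenyl (a 1.3-fold higher number from compound 1 to compound 4 (0.11 log units; within the scatter)). Lengthening methyl to ethyl on the ring gives a step of the same kind (a 1.5-fold lower number from compound 2 to compound 4 (0.16 log units; within the scatter)), so this position has now taken chloro, methyl, dimethyl and ethyl substitution on the phenyl ring with no step beyond the scatter. No supporting data on hand explain how closely the four values lie.

Whether any group at this position can carry the number beyond the scatter remains open, as all four compounds shown carry small carbon or chlorine substituents; an amine, a carboxylic acid or a longer chain such as n-butyl on the phenyl ring would test this. Also open, as far as these compounds go, is whether the place of the substituent on the ring matters, a question that the pair 3-chlorophenyl and 4-ethylphenyl would address alongside compound 3 and compound 4.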